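This account rests on a few compounds, and the source may have more. Where it says the series, first, only, none or still open, it means among the compounds named here.

Measured so far in an ADME assay on the whole organism for inhibition, with Echinochloa crus-galli var. formosensis as the target, with a stated time of 4 days; on this read-out lower numbers stand for stronger inhibition and higher numbers for weaker inhibition:

Compound 1, `CCN(c1nc(Cl)nc(N[C@H](C)c2ccccc2)n1)C(C)C`, gives 52500 nM.
Compound 2, `CCCN(C)c1nc(Cl)nc(N[C@H](C)c2ccccc2)n1`, gives 9770 nM.
Compound 3, `CCN(c1nc(Cl)nc(N[C@@H](C)c2ccccc2)n1)C(C)C`, gives 229 nM.

Compounds 1 and 3 share every atom and bond; (the two compounds have the same atoms and bonds and differ only in configuration as drawn: 1 of 1 stereo elements differ; a stereocentre at a saturated chain carbon is drawn R in compound 1 and S in compound 3). That single difference brings a 230-fold lower number from compound 1 to compound 3 (2.36 log units; beyond the scatter), which rests on (the fact that compounds 1 and 3 differ only in the configuration as drawn). Compound 3 thus stands with the lowest number of the three in this assay, and both gaps to the others are beyond the scatter.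

The second kind of change is a swap of the amine on the shared core: methyl(propyl)amino in place of ethyl(isopropyl)amino on an aromatic carbon. It gives a 5.4-fold lower number from compound 1 to compound 2 (0.73 log units; beyond the scatter).

Compound 4, `CCCN(C)c1nc(Cl)nc(N[C@@H](C)c2ccccc2)n1`, is not yet measured. It carries the same change, now made on compound 3: methyl(propyl)amino in place of ethyl(isopropyl)amino on an aromatic carbon. Among the compounds with values here, the surroundings of the swapped group are the same in both pairs, so this is the same change, and the step is expected to look like the earlier one, a 4.6-fold lower number from compound 3 to compound 4 (0.66 log units; beyond the scatter), because the one measured example of it is a 5.4-fold lower number from compound 1 to compound 2 (0.73 log units; beyond the scatter). On that basis compound 4 is estimated at 50 nM in this assay, within roughly 12 nM to 250 nM.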

Compound 4, half-maximal inhibitory concentration: 380 nM
Compound 4: middle estimate off by 7.6-fold (0.88 log units), on the low side; measured number above the stated range.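

In this assay, methyl(propyl)amino in place of ethyl(isopropyl)amino gives a 1.7-fold higher number from compound 3 to compound 4 (0.22 log units; within the scatter), so on this core the swap brings no measurable change. The step therefore did not carry over from one configuration of the stereocentre to the other, even though the surroundings of the swapped group are the same in both pairs: the same change on two cores in this assay, a 5.4-fold lower number (0.73 log units; beyond the scatter) from compound 1 to compound 2 and a 1.7-fold higher number (0.22 log units; within the scatter) from compound 3 to compound 4, 8.9-fold (0.95 log units) apart, beyond the scatter of two such steps. Within the data shown here, the configuration itself still matters with the new amine, at a 26-fold lower number from compound 2 to compound 4 (1.41 log units; beyond the scatter), but a single pair on each side shows only that this swap need not transfer, not why it failed to or how other changes would behave.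

From the compounds shown here alone, what stays open is whether other amines, such as diethylamino or a longer chain like dipropylamino, would also depend on the configuration drawn. Going by these compounds, it is also open whether the same pattern would hold with a methoxy group in place of the chloro group.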